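Dropping One Chloro Group: From Compound 2 to Compound 3

This account rests on a few compounds, and the source may have more. Where it says the series, first, only, none or still open, it means among the compounds named here.

Compound 1 `ClCc1ccc(Cn2cnc3c(Cl)ncnc32)cc1` carries the shared core with a single chloro group. In a functional assay on RXF 393 cells (Homo sapiens) for cytotoxicity, read by sulforhodamine B assay, with a stated time of 48 h (on this read-out lower numbers stand for higher toxicity in this test and higher numbers for lower toxicity in this test), compound 1 reaches only a limit of the test, > 100000 nM. Compound 2 `ClCc1ccccc1Cn1cnc2c(Cl)nc(Cl)nc21` bears two chloro groups on the core; in this assay compound 2 has no single number, its result being "not determined" (no result reported). Among the measured compounds shown here, the one further value shown, that of compound 1, sits at the limit (the limit of > 100000 nM in this assay, at which 1 of the 2 values shown sits). Compound 3 `ClCc1ccccc1Cn1cnc2c(Cl)ncnc21` differs from compound 2 by hydrogen in place of chloro on an aromatic carbon. For the measured compounds named here, no measured step exists in this assay, so no size or direction of change beyond the scatter can be expected from the data. Compound 3 is estimated at 100000 nM, with a range from 20000 nM to 300000 nM, most likely again reported only as a limit.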

Compound 3, concentration lethal to 50% of the cells: 7410 nM
For compound 3 the middle estimate is 13-fold (1.13 log units) above the measured one; measured number below the stated range.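

Among the compounds shown here, compound 2 gives no single number in this assay, so no step from it to compound 3 can be read. The compounds shown leave open how the chloro group between two ring nitrogen atoms affects toxicity in this test.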